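Methyl to Chloro on an Aromatic Ring of Compound 3

The source may hold more compounds than are shown below. What is called first, only, known or untested is meant among the compounds shown, and "the series" means these compounds.

Of the compounds shown here, three built on a shared core have been tested in a functional assay on HeLa cells (Homo sapiens) for inhibition, read by sulforhodamine B assay, with a stated time of 48 h; on this read-out lower numbers stand for stronger inhibition of growth and higher numbers for weaker inhibition of growth. Compound 1 `COC(=O)[C@@]1(C)CCC=C2[C@@H]1CC[C@@H](C)[C@]2(C)Cc1c(C)[nH]c2ccc(Br)cc12` gives 11000 nM. Compound 2 `COC(=O)[C@@]1(C)CC[C@@H]2C3=C1CC[C@@H](C)[C@]3(C)C[C@@H]1c3cc(Br)ccc3N[C@H]21` gives 25000 nM in this assay. Compound 3 `COC(=O)[C@@]1(C)CC[C@@H]2C3=C1CC[C@@H](C)[C@]3(C)C[C@@H]1c3cccc(C)c3N[C@H]21` gives 22000 nM in this assay. All three numbers lie within the usual scatter of one another, so none can be set apart: compound 3 sits closest to compound 2, and its widest gap is to compound 1, which still falls within the scatter.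

Compound 4 `COC(=O)[C@@]1(C)CC[C@@H]2C3=C1CC[C@@H](C)[C@]3(C)C[C@@H]1c3cccc(Cl)c3N[C@H]21` has not yet been measured. It differs from compound 3 in one place: chloro in place of methyl on an aromatic carbon. Within the data shown here, no pair of measured compounds shows this same change, so there is no direct guide to its size. With nothing in the measured set pointing either way, the change is expected to leave the number roughly where compound 3 stands, with no step beyond the scatter.

Compound 4 is therefore estimated to give 20000 nM in this assay, with a plausible range from 8000 nM to 50000 nM. That estimate means an expected step of a 1.1-fold lower number from compound 3 to compound 4 (0.04 log units; within the scatter) no larger than the scatter.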

Compound 4, concentration for 50% growth inhibition: 31000 nM
Compound 4: the middle estimate sits 1.6-fold (0.19 log units) below what was measured, and the stated range covers the measured number.
By their numbers in this assay, from the lowest: compounds 1, 3, 2 and 4 (each within the scatter of the next, the first and the last beyond it).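

In this assay, among these compounds, placing chloro where methyl stood on this aromatic carbon, ortho to a fused ring and meta to a fused ring, gives a 1.4-fold higher number from compound 3 to compound 4 (0.15 log units; within the scatter) as the first direct reading of this change on the shared core. At this position, then, the read-out does not tell the two groups apart, even though they differ in their atoms and each adds a single heavy atom. Nothing measured here accounts for this result.

Going by these compounds, whether an amine, a carboxylic acid or a longer chain such as propyl on the same aromatic carbon would move the number beyond the scatter remains open. So does the question of whether chloro in place of methyl would give a similarly small step on another aromatic carbon of the core.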